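Removing the Ring Fluorine from a Carbamate Lactone

The source may report more compounds than this note shows. Statements on the series, on what has been measured and on what is new or still open speak of the compounds shown alone.

compound 1, `C=C1C(=O)OC[C@H]1CCOC(=O)Nc1ccc(Cl)cc1`: 390 nM
compound 2, `C=C1C(=O)OC[C@H]1CCOC(=O)Nc1ccc(C(=O)OCCCC)cc1`: 430 nM
compound 3, `C=C1C(=O)OC[C@H]1CCOC(=O)Nc1ccccc1F`: 350 nM

In a functional assay on RAW264.7 cells (Mus musculus) for inhibition, with a stated time of 30 min (on this read-out higher numbers stand for weaker inhibition and lower numbers for stronger inhibition), compound 3 gives the lowest of the three numbers, yet compound 1 with 390 nM and compound 2 with 430 nM both sit within the scatter of it, so the three cannot be ranked. Compound 4, `C=C1C(=O)OC[C@H]1CCOC(=O)Nc1ccccc1`, differs from compound 3 by hydrogen in place of fluoro on an aromatic carbon. Within the data shown here, the only measured step, a 1.1-fold higher number from compound 1 to compound 2 (0.04 log units; within the scatter), swaps one substituent for another and stays within the scatter; no measured step removes a substituent outright. The data therefore give no ground for a shift, and compound 4 is expected to remain close to compound 3, as a 1.1-fold higher number from compound 3 to compound 4 (0.04 log units; within the scatter). For compound 4 the estimate in this assay is 380 nM, with a range from 200 nM to 750 nM.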

Compound 4, half-maximal inhibitory concentration: 390 nM
Beside the measured number, compound 4's estimate is 1.0-fold (0.01 log units) below it, within the range that was stated.
By their numbers in this assay, from the lowest: compounds 3, 1, 4 and 2 (each within the scatter of the next).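

Hydrogen in place of fluoro, a step that takes a substituent away outright, stays within the scatter in this assay (a 1.1-fold higher number from compound 3 to compound 4 (0.05 log units; within the scatter)). Hydrogen in place of butoxycarbonyl (a 1.1-fold lower number from compound 2 to compound 4 (0.04 log units; within the scatter)) or of chloro (no change at the digits printed from compound 1 to compound 4 (within the scatter)) also stays within the scatter, so none of these three substituents is shown to be needed on the aromatic ring. No evidence at hand explains why these steps are so small.

As far as these compounds go, whether an amine or a carboxylic acid on that ring would shift the number stays open. So does the effect of a longer chain in the shared core.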